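The compounds below may be only part of what the source reports. "The series", "measured", "known", "first", "only" and "open" are said of these compounds alone.

Working notes on the series. The property followed is an assay on isolated protein for agonist activity at nuclear receptor subfamily 1 group D member 1 (Homo sapiens), read by FRET; a higher number here means that more compound is needed for the effect, a lower number that less compound is needed. Compound 1 `Cn1nc(Oc2cc(C(F)(F)F)ccc2-c2ccsc2Cl)c2sccc2c1=O` gives 520 nM in this assay. Going by the values given here, compound 2 `Cc1cc(Cl)cc(CN(Cc2ccc(Cl)cc2)Cc2ccc([N+](=O)[O-])s2)c1` gives 50 nM in this assay, and the two values of compound 1 and compound 2 are what the numbers show for those structures; no single-point step between them is given. Compound 3 `FC(F)(F)c1ccc(-c2cncnc2)c(Oc2ccc3nnc(Cl)n3n2)c1` is different in kind: in this assay compound 3 returns only a limit, < 5000 nM, and not a number. This rests on (the limit of < 5000 nM in this assay, at which 1 of the 3 values shown sits), so compound 3 cannot be placed against compound 1 or compound 2 on the scale.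

The step to follow is from compound 3 to compound 4 `FC(F)(F)c1ccc(-c2cccnc2)c(Oc2ccc3nnc(Cl)n3n2)c1`. The change is pyridin-3-yl in place of pyrimidin-5-yl on an aromatic carbon, in words pyridin-3-yl in place of pyrimidin-5-yl on an aromatic carbon, ortho to a large group and para to a trifluoromethyl group. Among the compounds with values here, no measured pair differs in exactly this way, so there is no recorded step to lean on. The starting point is itself a limit, which leaves the direction open; no shift beyond the scatter is assumed either way, and a real chance remains that compound 4 also returns only a limit.

The estimate for compound 4 in this assay is 3000 nM, with a range from 700 nM to 12000 nM, which corresponds to an expected step that the limit leaves unreadable from compound 3 to compound 4.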

Compound 4, half-maximal effective concentration: < 1000 nM
Compound 4: no number, only a limit; the forecaster's own chance of this, stated with the estimate: 45%; middle value at least 3.0-fold (0.47 log units) away from the limit.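

Compound 3 and compound 4 each return only a limit in this assay, and no step can be read for pyridin-3-yl in place of pyrimidin-5-yl. The compounds shown leave open the size and direction of this exchange, and where compound 4 stands on the scale against compound 1 and compound 2.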